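This account rests on a few compounds, and the source may have more. Where it says the series, first, only, none or still open, it means among the compounds named here.

Within the data shown here, the series shares one core, and the three measured members are compound 1 `CCOC(=O)C1=C(Nc2ccc(OC)c(OC)c2)S/C(=C\c2ccc[nH]2)C1=O`, compound 2 `CCOC(=O)C1=C(Nc2ccc(F)cc2)S/C(=C\c2ccc[nH]2)C1=O` and compound 3 `CCOC(=O)C1=C(Nc2ccc(C(F)(F)F)cc2)S/C(=C\c2ccc[nH]2)C1=O`. In a functional assay on JAR cells (Homo sapiens) for inhibition, read by MTT assay, with a stated time of 72 h, tested at 10 uM (on this read-out higher numbers stand for more inhibition at the one concentration tested (going by the name of the read-out) and lower numbers for less inhibition), compound 2 gives 61.5%, the highest of the three numbers; compound 1 gives 47.9% and compound 3 gives 38.5%, both beyond the scatter below it. The unmeasured member is compound 4 `CCOC(=O)C1=C(Nc2cccc([N+](=O)[O-])c2)S/C(=C\c2ccc[nH]2)C1=O`, which differs from compound 2 in one place: 3-nitrophenyl in place of 4-fluorophenyl on an amine nitrogen. The measured step that comes nearest to this change is a number 23 percentage points lower from compound 2 to compound 3 (beyond the scatter), where a larger group on the same ring took the read-out down. The pair of compound 2 and compound 1 shows a lower number for the ring with two methoxy groups as well. Since every change to the ring attached to the amine nitrogen so far lowered the number from compound 2, a downward step is expected here too, of size a number 16.5 percentage points lower from compound 2 to compound 4 (beyond the scatter). Compound 4 is therefore estimated at 45%, in a range from 25% to 65%.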

Compound 4, a percentage reported as inhibition, at one concentration (the size of the read-out at that concentration, not a potency): 57.4%
Beside the measured number, compound 4's estimate is 12.4 percentage points below it; the range from low to high includes it.
By their numbers in this assay, from the lowest: compounds 3, 1, 4 and 2 (each within the scatter of the next, the first and the last beyond it).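

In this assay, replacing 4-fluorophenyl with 3-nitrophenyl on the amine nitrogen gives a number 4.1 percentage points lower from compound 2 to compound 4 (within the scatter), whereas the trifluoromethyl replacement gave a number 23 percentage points lower from compound 2 to compound 3 (beyond the scatter). The earlier compounds shown here showed only numbers beyond the scatter below compound 2 for changes to this ring, but compound 4 shows that a ring with more heavy atoms and with hydrogen-bond acceptors can stay within the scatter of compound 2, so a change at this position does not by itself take the number down. No supporting data explain why these two replacements differ.

The compounds shown leave open whether a ring carrying an amine or a carboxylic acid would also stay within the scatter of compound 2. They also leave open how a longer chain in place of the ring on the amine nitrogen would read.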